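Replacing the Hydroxycarbamoyl End of Compound 3

The compounds below may be only part of what the source reports. "The series", "measured", "known", "first", "only" and "open" are said of these compounds alone.

In a functional assay on CNE-2 cells (Homo sapiens) for inhibition, read by MTT assay, with a stated time of 72 h (on this read-out lower numbers stand for stronger inhibition and higher numbers for weaker inhibition), compound 1 `Nc1nc2cc(-c3nn(CCCCC(=O)NO)c4ncnc(N)c34)ccc2o1` gives only a limit of the assay, > 50000 nM. Compound 2 `Nc1nc2cc(-c3nn(CCCCCC(=O)NO)c4ncnc(N)c34)ccc2o1` gives 37600 nM. Among the compounds with values here, compound 3 `Nc1nc2cc(-c3nn(CCCCCCCCC(=O)NO)c4ncnc(N)c34)ccc2o1` gives 3240 nM, the lowest number so far. Longer chains ending in hydroxycarbamoyl track with lower numbers: an at least 1.3-fold lower number from compound 1 to compound 2 (0.12 log units; that floor lies within the scatter), a 12-fold lower number from compound 2 to compound 3 (1.06 log units; beyond the scatter) and an at least 15-fold lower number from compound 1 to compound 3 (1.18 log units; beyond the scatter). Compound 4 `CNC(=O)CCCCCCCn1nc(-c2ccc3oc(N)nc3c2)c2c(N)ncnc21` has methylcarbamoyl in place of (hydroxycarbamoyl)methyl, on a saturated chain carbon, seven bonds along the chain from an aromatic nitrogen: methylcarbamoyl in place of (hydroxycarbamoyl)methyl on a saturated chain carbon, seven bonds along the chain from an aromatic nitrogen. Within the data shown here, no measured compound lacks the hydroxycarbamoyl end, so the size of this change is uncertain. The large gain seen in a 12-fold lower number from compound 2 to compound 3 (1.06 log units; beyond the scatter) suggests that the chain end matters, so a loss is expected. The expected step is a 7.7-fold higher number from compound 3 to compound 4 (0.89 log units; beyond the scatter). Compound 4 is estimated at 25000 nM, within an expected range of 7000 nM to 80000 nM.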

Compound 4, half-maximal inhibitory concentration: 2250 nM
Compound 4: the middle estimate sits 11-fold (1.05 log units) above what was measured; measured number outside the range, below it.
By their numbers in this assay, from the lowest: compounds 4 and 3 (each within the scatter of the next); then compound 2. At a limit, above all of these: compound 1.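

Compound 4 lacks the hydroxycarbamoyl end, yet it cannot be told apart from compound 3 in this assay (a 1.4-fold lower number from compound 3 to compound 4 (0.16 log units; within the scatter)), so in this cell read-out that end is not needed on this long chain. Compound 4 also stands well clear of the compound with the shorter chain (a 17-fold lower number from compound 2 to compound 4 (1.22 log units; beyond the scatter)). The step from the shortest chain is large but only a floor (an at least 22-fold lower number from compound 1 to compound 4 (1.34 log units; beyond the scatter)), since compound 1 sits at a limit of the assay: the limit of > 50000 nM in this assay, at which 1 of the 4 values shown sits.

On these data alone, whether the number follows the chain rather than its end stays open. An amine or a carboxylic acid at the same chain end, or a longer chain, would help to separate the two.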